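A few compounds are considered here, and "the series" means these few. Any claim that something is new, unique, unknown or untested is made for them only; others in the source may bear on it.

Compound 1 `CCCCc1nc(=O)c(S(=O)(=O)c2ccc(-c3ccc(F)nc3)cc2)c(O)n1-c1c(OC)cccc1OC` and compound 2 `CCCCc1nc(=O)c(S(=O)(=O)c2ccc(-n3ccccc3=O)cc2)c(O)n1-c1c(OC)cccc1OC` share one core and differ by a single change, (a group of 7 heavy atoms (5 carbon, 1 nitrogen, 1 oxygen; one six-membered aromatic ring with 1 hetero atom) in place of a group of 7 heavy atoms (5 carbon, 1 nitrogen, 1 fluorine; one six-membered aromatic ring with 1 hetero atom), on an aromatic carbon). In an ADME assay for permeability, using PAMPA, at pH 5.5 (on this read-out lower numbers stand for lower permeability and higher numbers for higher permeability), compound 1 gives 516 nm/s, while compound 2 gives 12 nm/s, so the change produced a 43-fold lower number from compound 1 to compound 2 (1.63 log units; beyond the scatter). Compound 3 `CCCCc1[nH]c(=O)c(S(=O)(=O)c2ccc(-c3ccc(F)nc3)cc2)c(O)c1-c1c(OC)cccc1OC` is built on another core; the difference between the two cores is not broken down here, and in this assay compound 3 is reported as "not determined" (no result reported), so no number is available for it. Compound 4 `CCCCc1[nH]c(=O)c(S(=O)(=O)c2ccc(-n3ccccc3=O)cc2)c(O)c1-c1c(OC)cccc1OC` stands to compound 3 as compound 2 stands to compound 1, through the same change, (a group of 7 heavy atoms (5 carbon, 1 nitrogen, 1 oxygen; one six-membered aromatic ring with 1 hetero atom) in place of a group of 7 heavy atoms (5 carbon, 1 nitrogen, 1 fluorine; one six-membered aromatic ring with 1 hetero atom), on an aromatic carbon), at the same place. With no number for compound 3, the expectation for compound 4 rests on the step of a 43-fold lower number from compound 1 to compound 2 (1.63 log units; beyond the scatter) and on the value of compound 2, 12 nm/s. Compound 4 is therefore expected to give about 12 nm/s in this assay, estimated to lie between 3 nm/s and 60 nm/s.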

Compound 4, apparent permeability: 177 nm/s
Compound 4: middle estimate off by 15-fold (1.17 log units), on the low side; the whole stated range lies below it.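

For the compounds shown here, compound 3 has no number in this assay, and no step from it to compound 4 can be read. The compounds shown leave open whether the same change acts alike on both cores. No measured evidence bears on this result.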